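Working notes: compound 4 set against the measured series

A few compounds are considered here, and "the series" means these few. Any claim that something is new, unique, unknown or untested is made for them only; others in the source may bear on it.

All numbers below come from a functional assay on MDA-MB-231 cells (Homo sapiens) for cytotoxicity, read by MTT assay, with a stated time of 48 h; a lower number here means a stronger inhibitor, a higher number a weaker inhibitor.

compound 1 `COc1ccc(-c2nnnn2-c2cc(OC)c(OC)c(OC)c2)cc1N`: 3170 nM
compound 2 `COc1cc(-n2nnnc2-c2ccc(OCC3CC(c4cccc(Cl)c4)=NO3)c(N)c2)cc(OC)c1OC`: 2180 nM
compound 3 `COc1cc(-n2nnnc2-c2ccc(OCC3CC(c4ccc(OC)c(OC)c4OC)=NO3)c(N)c2)cc(OC)c1OC`: 3540 nM

Compound 1 has the second highest of the three numbers; its nearest neighbour is compound 3 and its furthest is compound 2, and both gaps lie within the scatter, so no order among the three can be read.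

Compound 4 `COc1cc(-n2nnnc2-c2ccc(OCC3CC(c4ccccc4F)=NO3)c(N)c2)cc(OC)c1OC` is not yet measured. It differs from compound 1 by a group of 12 heavy atoms (9 carbon, 1 nitrogen, 1 oxygen, 1 fluorine; one five-membered non-aromatic ring with 2 hetero atoms, one six-membered aromatic ring of carbon only) in place of a hydrogen atom, on a saturated chain carbon bound to an oxygen on an aromatic ring

Among the compounds with values here, two measured steps bear on this. The step of a 1.5-fold lower number from compound 1 to compound 2 (0.16 log units; within the scatter) is the same kind of change, with chlorine where compound 4 carries fluorine, and it stayed within the scatter. The step of a 1.6-fold higher number from compound 2 to compound 3 (0.21 log units; within the scatter) shows that swapping the aromatic ring on the carbon with a double bond to nitrogen also stayed within the scatter. Neither step gives grounds for a shift beyond the scatter in this assay from this kind of change.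

The expected step is therefore a 1.2-fold lower number from compound 1 to compound 4 (0.09 log units; within the scatter), essentially none. Compound 4 is estimated at 2600 nM, with a range from 1300 nM to 5200 nM.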

Compound 4, half-maximal inhibitory concentration: 2400 nM
The estimate for compound 4 lay 1.1-fold (0.03 log units) above the measured number, within the range that was stated.
By their numbers in this assay, from the lowest: compounds 2, 4, 1 and 3 (each within the scatter of the next).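

In this assay, the fluorine-bearing group of 12 heavy atoms on the saturated chain carbon bound to an oxygen on an aromatic ring gives a step within the scatter (a 1.3-fold lower number from compound 1 to compound 4 (0.12 log units; within the scatter)), so this position now has two such groups, one with chlorine and one with fluorine, that leave the number where the hydrogen of the smaller compound had it. On the carbon with a double bond to nitrogen, 2-fluorophenyl does not separate from 3-chlorophenyl (a 1.1-fold higher number from compound 2 to compound 4 (0.04 log units; within the scatter)) or from 2,3,4-trimethoxyphenyl (a 1.5-fold lower number from compound 3 to compound 4 (0.17 log units; within the scatter)), so three differently substituted phenyl rings at this place now give numbers that cannot be told apart, and none of the four compounds can be ranked. No measurement at hand speaks to why these steps are so small.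

Still open, from the compounds shown here alone, is whether a ring of another kind at that carbon, such as a pyridine, or a phenyl ring carrying a carboxylic acid or an amine, would give a step beyond the scatter. Also open, going by these compounds, is whether a longer saturated chain on the oxygen on the aromatic ring would leave the number as flat as the present group does.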